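This account rests on a few compounds, and the source may have more. Where it says the series, first, only, none or still open, it means among the compounds named here.

Measured so far:
compound 1, `Nc1cc(N)c2nc(-c3ccccc3)c(Oc3ccc(Cl)c(Cl)c3)nc2c1`: < 100000 nM
compound 2, `Nc1cc(N)c2nc(-c3ccccc3)c(NCc3ccc(Cl)c(Cl)c3)nc2c1`: 3720 nM

In a functional assay on RPMI8266 cells (Homo sapiens) for inhibition, read by sulforhodamine B assay, with a stated time of 48 h (a lower number here means a stronger inhibitor of growth, a higher number a weaker inhibitor of growth), compound 1 gives a limit rather than a number, < 100000 nM (the limit of < 100000 nM in this assay, at which 1 of the 2 values shown sits). Compound 2 gives the one number shown in this assay, 3720 nM, and is the reference for the next step. Compound 3, `COc1ccc(CNc2nc3cc(N)cc(N)c3nc2-c2ccccc2)cc1OC`, is not yet measured in this assay. It differs from compound 2 by 3,4-dimethoxyphenyl in place of 3,4-dichlorophenyl on a saturated chain carbon bound to a nitrogen on an aromatic ring. Among the measured compounds shown here, no measured step of this kind exists, so size and direction are open. For compound 3 a step within the scatter or a modest weakening is expected, a 1.6-fold higher number from compound 2 to compound 3 (0.21 log units; within the scatter). Compound 3 is estimated at 6000 nM, between 1500 nM and 25000 nM.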

Compound 3, concentration for total growth inhibition: 7240 nM
For compound 3 the middle estimate is 1.2-fold (0.08 log units) below the measured one; the measured number falls inside the stated range.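

In this assay, among the compounds shown here, 3,4-dimethoxyphenyl in place of 3,4-dichlorophenyl on a saturated chain carbon bound to a nitrogen on an aromatic ring gives a 1.9-fold higher number from compound 2 to compound 3 (0.29 log units; within the scatter), the first measured step at this position. The two substituted rings are therefore not told apart here, although the entering group carries 2 hydrogen-bond acceptors and the leaving group none. No measured property shown here bears on this step.

On these data alone, whether an unsubstituted phenyl, or a ring carrying an amine or a carboxylic acid, would give a step beyond the scatter stays open. As far as these compounds go, a longer chain between the nitrogen and the ring is equally open.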